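A few compounds are considered here, and "the series" means these few. Any claim that something is new, unique, unknown or untested is made for them only; others in the source may bear on it.

Measured so far in a functional assay on NCI-H460 cells (Homo sapiens) for cytotoxicity, read by MTT assay, with a stated time of 72 h; a lower number here means a stronger inhibitor, a higher number a weaker inhibitor:
- compound 1 `CC1CCN(Cc2ccc3nc(NC(=O)N/N=C4\C(=O)Nc5ccc(F)cc54)sc3c2)CC1`: 1430 nM
- compound 2 `CCN(CC)Cc1ccc2nc(NC(=O)N/N=C3\C(=O)Nc4ccc(F)cc43)sc2c1`: 1060 nM
- compound 3 `CCN(CC)Cc1ccc2nc(NC(=O)N/N=C/c3cn(Cc4ccccc4)c4ccccc34)sc2c1`: 450 nM

Compound 1 and compound 2 share a core; the change 4-methylpiperidin-1-yl in place of diethylamino on a saturated chain carbon bound to an aromatic carbon gives a 1.3-fold higher number from compound 2 to compound 1 (0.13 log units; within the scatter). Compound 3 has a different core, and the difference between the two cores is not broken down here; compound 3 gives the lowest number of the three, and its steps to compound 2 and compound 1 lie beyond the scatter.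

Compound 4 `CC1CCN(Cc2ccc3nc(NC(=O)N/N=C/c4cn(Cc5ccccc5)c5ccccc45)sc3c2)CC1` is not yet measured in this assay. It differs from compound 3 by 4-methylpiperidin-1-yl in place of diethylamino on a saturated chain carbon bound to an aromatic carbon, the same change made from compound 2 to compound 1, at the same place. The step in this assay is expected to be a 1.3-fold higher number from compound 3 to compound 4 (0.11 log units; within the scatter), resting on the earlier step of a 1.3-fold higher number from compound 2 to compound 1 (0.13 log units; within the scatter). Compound 4 is therefore estimated at 580 nM, expected within 300 nM to 1200 nM.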

Compound 4, half-maximal inhibitory concentration: 1910 nM
The estimate for compound 4 lay 3.3-fold (0.52 log units) below the measured number, and the stated range ends below it.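

In this assay, the exchange of diethylamino for 4-methylpiperidin-1-yl gives a 4.2-fold higher number from compound 3 to compound 4 (0.63 log units; beyond the scatter), and the size of the step does not carry over from the core of compound 1 to the core of compound 3: the same change on two cores in this assay, a 1.3-fold higher number (0.13 log units; within the scatter) from compound 2 to compound 1 and a 4.2-fold higher number (0.63 log units; beyond the scatter) from compound 3 to compound 4, 3.1-fold (0.50 log units) apart, beyond the scatter of two such steps
In this series, a step read on one core is therefore a poor guide to the same change on the other. Two pairs do not show which part of the cores accounts for the gap, or how the change behaves on any further core.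

Open, as far as these compounds go, is whether other amines on the same carbon, such as piperidin-1-yl without the methyl, pyrrolidin-1-yl or morpholin-4-yl, split between the two cores in the same way. Also open, from the compounds shown here alone, is whether the methyl or the ring carries the step on the core of compound 3.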